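The compounds below may be only part of what the source reports. "The series", "measured", "known", "first", "only" and "open" are said of these compounds alone.

Measured so far:
- compound 1, `CCCS(=O)(=O)c1cccc(C#Cc2cc(Cl)ccc2OCC(=O)O)c1`: 9 nM
- compound 2, `COc1ccccc1C#Cc1cc(Cl)ccc1OCC(=O)O`: 190 nM
- compound 3, `Cc1ccc(S(=O)(=O)Cc2ccccc2)cc1C#Cc1cc(Cl)ccc1OCC(=O)O`: 5 nM

These three compounds share a core and were tested in an assay on CHO cells for displacement of a labelled ligand from prostaglandin D2 receptor 2 (Homo sapiens), read by scintillation counting; a higher number here means a weaker inhibitor, a lower number a stronger inhibitor. Compound 3 has the lowest number of the three. Its gap to compound 1 is within the scatter of repeated measurements, so the two cannot be ranked against each other; compound 2, carrying a methoxy group in place of a sulfonyl group, lies well beyond the scatter with the highest number.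

The next compound, compound 4, `Cc1ccc(S(=O)(=O)CC(C)C)cc1C#Cc1cc(Cl)ccc1OCC(=O)O`, has not yet been measured in this assay. It differs from compound 3 in one place: isopropyl in place of phenyl on a saturated chain carbon bound to a sulfonyl sulfur. Read one bond further out, this is benzylsulfonyl to isobutylsulfonyl.

A small step, or none beyond the scatter, is expected because compound 1 gives 9 nM with a propylsulfonyl group, showing that a saturated chain on the sulfonyl sulfur is tolerated. The expected step is a 1.6-fold higher number from compound 3 to compound 4 (0.20 log units; within the scatter). Compound 4 is therefore estimated at 8 nM, with a range from 3 nM to 25 nM.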

Compound 4, inhibition constant: 3 nM
The estimate for compound 4 lay 2.7-fold (0.43 log units) above the measured number, and the stated range covers the measured number.
By their numbers in this assay, from the lowest: compounds 4, 3 and 1 (each within the scatter of the next, the first and the last beyond it); then compound 2.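

Replacing phenyl with isopropyl on this saturated chain carbon gives a 1.7-fold lower number from compound 3 to compound 4 (0.22 log units; within the scatter) in this assay, so compound 3 and compound 4 cannot be told apart. The aromatic ring of the benzylsulfonyl group is therefore not needed at this position to keep a low number: compound 4, with no ring there and fewer heavy atoms, gives 3 nM in this assay. No measurement shown explains why the two groups read alike.

On these data alone, it remains open how far this tolerance extends: whether a tert-butyl group, a cyclohexyl ring or a longer chain on the same carbon would keep the number this low. It is equally unknown whether an amine or a carboxylic acid at that place would be accepted.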